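Swapping the pendant aryl group on a kinase-binding core

This account rests on a few compounds, and the source may have more. Where it says the series, first, only, none or still open, it means among the compounds named here.

Measured compounds:
compound 1, `CCCS(=O)(=O)Nc1ccc(F)c(C(=O)c2n[nH]c3ncc(-c4cccc(Cl)c4)cc23)c1F`, gives 40% in an assay for binding affinity to dual specificity mitogen-activated protein kinase kinase 4 (Homo sapiens), read by KINOMEscan, tested at 100 nM; a higher number here means a weaker effect of the compound at the concentration tested, a lower number a stronger effect
compound 2, `CCCS(=O)(=O)Nc1ccc(F)c(C(=O)c2n[nH]c3ncc(-c4ccccc4F)cc23)c1F`, gives 2%
compound 3, `CCCS(=O)(=O)Nc1ccc(F)c(C(=O)c2n[nH]c3ncc(-c4ccc(OC)cc4)cc23)c1F`, gives 4.2%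

Compound 3 stands second highest of the three numbers. Its nearest neighbour is compound 2, with a number 2.2 percentage points higher from compound 2 to compound 3 (within the scatter), while compound 1 lies far off, with a number 35.8 percentage points lower from compound 1 to compound 3 (beyond the scatter). Compound 4, `CCCS(=O)(=O)Nc1ccc(F)c(C(=O)c2n[nH]c3ncc(-c4cccc(N)c4)cc23)c1F`, carries the change (3-aminophenyl in place of 4-methoxyphenyl on an aromatic carbon). Among the measured compounds shown here, no measured step brings in a 3-aminophenyl, so the guidance is indirect: the large step from compound 1 to compound 3 shows the 3-chlorophenyl compound as the weaker one, and the small step from compound 2 to compound 3 shows two other aryl groups reading alike. The expected step of a number 3.8 percentage points higher from compound 3 to compound 4 (within the scatter) is therefore small, with the weaker reading of compound 1 kept within reach. Compound 4 is expected to give 8%, between 0.5% and 40%.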

Compound 4, a percentage reported as activity, at one concentration (the size of the read-out at that concentration, not a potency): 1.6%
Compound 4: middle estimate off by 6.4 percentage points, on the high side, and the stated range covers the measured number.
By their numbers in this assay, from the lowest: compounds 4, 2 and 3 (each within the scatter of the next); then compound 1.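

Amino in place of chloro at the same spot on the pendant ring gives, in this assay, a number 38.4 percentage points lower from compound 1 to compound 4 (beyond the scatter), so the weak reading of compound 1 goes with the chloro group and not with carrying a group at that spot as such. The other two steps, a number 2.6 percentage points lower from compound 3 to compound 4 (within the scatter) and a number 0.4 percentage points lower from compound 2 to compound 4 (within the scatter), put the 3-aminophenyl group level with the 4-methoxyphenyl and 2-fluorophenyl groups, leaving the 3-chlorophenyl group alone in standing apart. Nothing available explains the gap between chloro and amino. From the compounds shown here alone, whether a 4-chlorophenyl group, with the chlorine moved around the ring, or a 3-methoxyphenyl group would read like compound 1 or like compound 4 stays open.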